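This account rests on a few compounds, and the source may have more. Where it says the series, first, only, none or still open, it means among the compounds named here.

Compound 1 `COc1ccc(S(=O)(=O)N2CCc3cccc(-c4ccc(N)cc4)c32)cc1` — 249 nM
Compound 2 `COc1ccc(S(=O)(=O)N2CCc3cccc(-c4ccc([N+](=O)[O-])cc4)c32)cc1` — 52.5 nM
Compound 3 `COc1ccc(S(=O)(=O)N2CCc3cccc(-c4ccncc4)c32)cc1` — 96 nM

In a functional assay on KB cells (Homo sapiens) for inhibition, with a stated time of 72 h (a lower number here means a stronger inhibitor, a higher number a weaker inhibitor), compound 2 gives 52.5 nM, the lowest of the three numbers. Its distance from compound 3 is small, a 1.8-fold higher number from compound 2 to compound 3 (0.26 log units; within the scatter), whereas its distance from compound 1 is clear, a 4.7-fold lower number from compound 1 to compound 2 (0.68 log units; beyond the scatter). Compound 4 `COc1ccc(S(=O)(=O)N2CCc3cccc(-c4ccc(O)cc4)c32)cc1` is the next variation on this core: hydroxy in place of nitro on an aromatic carbon. The step that bears most directly on it is a 4.7-fold lower number from compound 1 to compound 2 (0.68 log units; beyond the scatter), where an amino group, which like hydroxy carries a hydrogen-bond donor, gave way to nitro and the number fell. Compound 3, with pyridin-4-yl at the same place, sits close to compound 2 and offers no further guidance on a hydroxy group. Replacing nitro by hydroxy is therefore expected to move the number back upward, roughly reversing the earlier step, which for compound 4 means an expected 3.0-fold higher number from compound 2 to compound 4 (0.48 log units; beyond the scatter). On this basis compound 4 is estimated at 160 nM, with a likely range from 60 nM to 420 nM.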

Compound 4, half-maximal inhibitory concentration: 129 nM
For compound 4 the middle estimate is 1.2-fold (0.09 log units) above the measured one, and the stated range covers the measured number.
By their numbers in this assay, from the lowest: compounds 2, 3, 4 and 1 (each within the scatter of the next, the first and the last beyond it).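

In this assay, exchanging nitro for hydroxy on the aromatic carbon para to a large group gives up part of the strength of compound 2 (a 2.5-fold higher number from compound 2 to compound 4 (0.39 log units; beyond the scatter)). Hydroxy and amino at this place cannot be told apart (a 1.9-fold lower number from compound 1 to compound 4 (0.29 log units; within the scatter)), so nitro now stands clear of both of these groups. The pattern does not extend to pyridin-4-yl, since compound 3 lies within the scatter of compound 2 and also of the new compound (a 1.3-fold higher number from compound 3 to compound 4 (0.13 log units; within the scatter)), leaving it unresolved from either side.

Nothing at hand accounts for these differences. The compounds shown leave open whether a nitrile or a carboxylic acid at the same place would stay with nitro or fall in with hydroxy and amino.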